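Removing the chloro from compound 3: working notes

This account rests on a few compounds, and the source may have more. Where it says the series, first, only, none or still open, it means among the compounds named here.

Measured in a functional assay on HeLa cells (Homo sapiens) for inhibition, read by MTT assay, with a stated time of 72 h; a lower number here means a stronger inhibitor, a higher number a weaker inhibitor:
- compound 1 `COc1cc(OC)c(OC)cc1/C=C/C(=O)c1ccc(Cl)cc1`: 36500 nM
- compound 2 `COc1cc(OC)c(OC)cc1/C=C/C(=O)c1cc(Cl)ccc1O`: > 150000 nM
- compound 3 `COc1cc(OC)c(OC)cc1/C=C/C(=O)c1ccc(Cl)c([N+](=O)[O-])c1`: 16500 nM

The entry for compound 2 at > 150000 nM is a limit of the assay and not a number. Compound 3 at 16500 nM holds the lower of the two actual numbers, and the other actual number belongs to compound 1 at 36500 nM.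

Next in the series is compound 4 `COc1cc(OC)c(OC)cc1/C=C/C(=O)c1cccc([N+](=O)[O-])c1`, still to be measured in this assay. It has hydrogen in place of chloro on an aromatic carbon, ortho to a nitro group and para to a large group: hydrogen in place of chloro on an aromatic carbon.

For the measured compounds named here, no measured step removes the chloro alone. The step of an at least 4.1-fold higher number from compound 1 to compound 2 (0.61 log units; beyond the scatter) leaves a chloro in the molecule and involves a limit, so it says little about this change. The closest guide is a 2.2-fold lower number from compound 1 to compound 3 (0.34 log units; beyond the scatter), a modest step on the same part of the molecule. On that basis a modest move is expected in this assay, more likely toward a higher number, though the direction is uncertain.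

The estimated step is a 1.5-fold higher number from compound 3 to compound 4 (0.18 log units; within the scatter), which is expected to be small. For compound 4 the estimated value is 25000 nM, with an expected range of 9000 nM to 70000 nM.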

Compound 4, half-maximal inhibitory concentration: 130000 nM
Beside the measured number, compound 4's estimate is 5.2-fold (0.72 log units) below it; measured number above the stated range.
By their numbers in this assay, from the lowest: compound 3; then compound 1; then compound 4. At a limit, above all of these: compound 2.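

In this assay, for the compounds shown here, this is the first reading of the chloro position on its own, on an aromatic carbon ortho to a nitro group and para to a large group, and the change is not neutral: a 7.9-fold higher number from compound 3 to compound 4 (0.90 log units; beyond the scatter). The earlier nitro step, a 2.2-fold lower number from compound 1 to compound 3 (0.34 log units; beyond the scatter), was read only with the chloro in place, so the lower number of compound 3 can now be seen to depend on the chloro being kept, and the nitro group without it does not hold that number. Compound 2 is the one entry at a limit and not a number, and any further change that weakens compound 4 could end at that same limit: the limit of > 150000 nM in this assay, at which 1 of the 4 values shown sits.

The series does not show whether the chloro matters to the same degree when no nitro group is present, since its removal has been read only in the nitro series. Nor does it show whether a fluoro, a bromo or a methyl group on this carbon would stay close to compound 3 or fall toward compound 4.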